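The source may hold more compounds than are shown below. What is called first, only, known or untested is meant among the compounds shown, and "the series" means these compounds.

Measured compounds in a functional assay on MCF7 cells (Homo sapiens) for cytotoxicity, tested at 10 uM; on this read-out higher numbers stand for more inhibition at the one concentration tested (going by the name of the read-out) and lower numbers for less inhibition:
compound 1 `O=Cc1c(-c2ccc(Cl)cc2)sc2ccccc12`: 69%
compound 2 `N#Cc1c(-c2ccc(Cl)cc2)sc2ccccc12`: 27%

Compound 2 stands lowest of the two numbers in this assay; its nearest neighbour is compound 1, and the only measured step, a number 42 percentage points lower from compound 1 to compound 2 (beyond the scatter), lies beyond the scatter, so on the numbers shown compound 2 gives the lower number of the pair.

Compound 3 `N#Cc1c(-c2ccccc2)sc2ccccc12` is not yet measured. It differs from compound 2 in one place: hydrogen in place of chloro on an aromatic carbon.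

Among the measured compounds shown here, none of the measured steps bears on this change. For the measured compounds named here, the one step, a number 42 percentage points lower from compound 1 to compound 2 (beyond the scatter), concerns the exchange of formyl for cyano and says nothing about the chloro group; compound 1 and compound 2 both carry the chloro group, so its contribution has not been isolated anywhere in the data. Going by the values given here, with no comparable step available, the expectation is that the change from compound 2 to compound 3 produces no step beyond the scatter, and the estimated step of a number 2 percentage points lower from compound 2 to compound 3 (within the scatter) is therefore set close to zero. Among the compounds with values here, compound 3 is accordingly expected to give 25% in this assay, with the range from 5% to 45% kept wide because the series holds no precedent for the removed chloro group.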

Compound 3, a percentage reported as inhibition, at one concentration (the size of the read-out at that concentration, not a potency): 51%
Compound 3: middle estimate off by 26 percentage points, on the low side; measured number outside the range, above it.
By their numbers in this assay, from the lowest: compound 2; then compound 3; then compound 1.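

In this assay, among the compounds shown here, hydrogen in place of chloro, on an aromatic carbon para to a large group, gives a number 24 percentage points higher from compound 2 to compound 3 (beyond the scatter), the first reading on this position. Compound 1 and compound 2 both carry the chloro group, so neither could show that this position affects the read-out, or that in the cyano pair the number is the higher one with hydrogen and the lower one with chloro. No measurement at hand bears on what lies behind this step.

Compound 1 has no hydrogen counterpart among the compounds shown, so it stays open whether the same exchange gives a step of similar size and direction with formyl in place of cyano. Also open, from the compounds shown here alone, is how other groups at this position would read out against hydrogen and chloro, for example a methoxy group, an amine or a carboxylic acid, and whether a chloro group at another carbon of the same ring would give a comparable number.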